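This account rests on a few compounds, and the source may have more. Where it says the series, first, only, none or still open, it means among the compounds named here.

Compound 2 (`NC(=O)NC(=O)c1ccc(F)c(NC(=O)CCl)c1`) stands at > 20000 nM in a functional assay on CCRF-CEM cells (Homo sapiens) for antiproliferative activity, read by trypan blue exclusion, with a stated time of 72 h (a lower number here means a stronger inhibitor, a higher number a weaker inhibitor), and this value is a limit of the assay, not a number. Compound 3 (`COc1ccc(C(=O)NC(N)=O)cc1NC(=O)CCl`) differs from it in one place: methoxy in place of fluoro on an aromatic carbon, ortho to a ((chloromethyl)carbonyl)amino group (methoxy in place of fluoro on an aromatic carbon). Compound 1 (`COc1ccc(C(=O)NC(N)=O)cc1NC(=O)CBr`) also carries methoxy and gives 1880 nM in this assay, so a large step towards stronger inhibition is expected. The expected step runs (an at least 4.0-fold lower number from compound 2 to compound 3 (0.60 log units; beyond the scatter)) towards a lower number. Compound 3 is estimated at 5000 nM (range 1800 nM to 15000 nM).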

Compound 3, half-maximal inhibitory concentration: > 20000 nM
Compound 3 ended at the assay's limit; the forecaster's own chance of this, stated with the estimate: 12%; middle value at least 4.0-fold (0.60 log units) away from the limit.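

In this assay compound 3 gives > 20000 nM, which is a limit of the assay and not a number. The change from fluoro to methoxy on this aromatic carbon therefore cannot be read, because both compounds end at the same limit: the limit of > 20000 nM in this assay, at which 2 of the 3 values shown sit. With methoxy held in place, chloro in place of bromo on a saturated chain carbon bound to a carbonyl carbon gives an at least 10-fold higher number from compound 1 to compound 3 (1.02 log units; beyond the scatter), so methoxy here does not by itself bring the activity of compound 1.

Open, as far as these compounds go, is how fluoro compares with methoxy when bromo stands on the chain, and whether an amine on this aromatic carbon would keep that activity.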